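Lengthening an Ether Side Chain: Compound 1 to Compound 3

The source may report more compounds than this note shows. Statements on the series, on what has been measured and on what is new or still open speak of the compounds shown alone.

The series rests on a shared core carried by compound 1 `COCc1c(C)coc1-c1ccc2c(c1OC)CCCC2(C)C` and compound 2 `CCOc1c(-c2occ(C)c2CO)ccc2c1CCCC2(C)C`. In a functional assay on KBVIN cells (Homo sapiens) for cytotoxicity, read by sulforhodamine B assay, with a stated time of 3 days (a higher number here means that more compound is needed for the effect, a lower number that less compound is needed), compound 1 gives 20.1 uM, the highest of the two numbers recorded, while compound 2 gives 15.3 uM; these two values sit within the usual scatter of each other, so nothing separates them. Compound 3 `CCOCc1c(C)coc1-c1ccc2c(c1OC)CCCC2(C)C` has not yet been measured in this assay. It differs from compound 1 by methyl in place of hydrogen on a saturated chain carbon bound to an oxygen on a saturated carbon, so that methoxymethyl becomes ethoxymethyl. Among the compounds with values here, no pair of measured compounds records a step of this kind, and there is thus no precedent in this set for what an added methyl on this chain does. Since compound 1 and compound 2, which differ at more than one place, still return values within the scatter, the account expects the step of a 1.1-fold lower number from compound 1 to compound 3 (0.05 log units; within the scatter) to be small, with no direction favoured beyond the scatter. Compound 3 is therefore estimated at 18 uM, with a range from 8 uM to 40 uM.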

Compound 3, concentration for half-maximal effect: 16.5 uM
For compound 3 the middle estimate is 1.1-fold (0.04 log units) above the measured one; the range from low to high includes it.
By their numbers in this assay, from the lowest: compounds 2, 3 and 1 (each within the scatter of the next).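

In this assay, within the data shown here, lengthening methoxymethyl to ethoxymethyl gives a 1.2-fold lower number from compound 1 to compound 3 (0.09 log units; within the scatter) and is the first step in this set confined to one place. The saturated chain carbon bound to an oxygen on a saturated carbon therefore has its first direct reading: methyl in place of hydrogen there gives a difference that the scatter cannot separate from none, something compound 1 and compound 2 could not show, as they differ at more than one place. No supporting measurement accompanies this result to explain it.

The compounds shown leave open whether a longer chain such as propoxymethyl, or a more different group such as an amine or a carboxylic acid at the end of this chain, would also stay within the scatter of compound 1. They also leave open whether the same change from methoxy to ethoxy at the other ether on the shared core would read the same way when taken as a single step, since compound 2 carries that ethoxy together with a second difference.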